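Methylsulfonyl on the Core: Compound 3 to Compound 4

The compounds below may be only part of what the source reports. "The series", "measured", "known", "first", "only" and "open" are said of these compounds alone.

Compound 1 `FC(F)(F)c1ccc(Nc2ncnc3sc(Nc4c(Cl)cccc4Cl)nc23)cc1` gives 3 nM in a functional assay on HEK293 cells for antagonist activity at transient receptor potential cation channel subfamily V member 1 (Rattus norvegicus), read by calcium flux; a lower number here means a stronger inhibitor, a higher number a weaker inhibitor.
Compound 2 `Cc1cccc(C)c1Nc1nc2c(Nc3ccc(C(F)(F)F)cc3)ncnc2s1` gives 6 nM in this assay.
Compound 3 `FC(F)(F)c1ccc(Nc2ncnc3sc(Nc4c(Cl)cccc4Cl)nc23)cc1Cl` gives 9 nM in this assay.

Compound 3 carries the highest of the three numbers. Its nearest neighbour is compound 2, and the two lie within the scatter of each other, so no order can be read from that pair. Its furthest neighbour is compound 1: a 3.0-fold higher number from compound 1 to compound 3 (0.48 log units; beyond the scatter), where chloro replaces hydrogen on an aromatic carbon of the trifluoromethylphenyl ring. The other measured step, a 2.0-fold higher number from compound 1 to compound 2 (0.30 log units; within the scatter), swaps the dichlorophenyl for a dimethylphenyl and stays within the scatter.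

Compound 4 `CS(=O)(=O)c1nc(Nc2ccc(C(F)(F)F)c(Cl)c2)c2nc(Nc3c(Cl)cccc3Cl)sc2n1` differs from compound 3 in one place: methylsulfonyl in place of hydrogen on an aromatic carbon. Neither measured step touches this carbon of the shared core; both concern the groups hanging from the nitrogens. Among the measured compounds shown here, no step therefore bears directly on the change, and the direction in this assay is open. With only the modest size of the two known steps as a guide, a similarly modest shift is expected, leaning toward a weaker number. Compound 4 is thus expected to give about 15 nM, within 3 nM to 80 nM. The expected step is a 1.7-fold higher number from compound 3 to compound 4 (0.22 log units; within the scatter).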

Compound 4, half-maximal inhibitory concentration: 77 nM
The estimate for compound 4 lay 5.1-fold (0.71 log units) below the measured number, and the stated range covers the measured number.
By their numbers in this assay, from the lowest: compounds 1, 2 and 3 (each within the scatter of the next, the first and the last beyond it); then compound 4.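

Among the compounds shown here, the carbon between two ring nitrogen atoms on the shared core carried hydrogen in all the earlier compounds, so compound 4 is the first to show that this position responds to substitution in this assay. Methylsulfonyl in place of hydrogen gives an 8.6-fold higher number from compound 3 to compound 4 (0.93 log units; beyond the scatter), a larger step than the chloro change on the trifluoromethylphenyl ring, a 3.0-fold higher number from compound 1 to compound 3 (0.48 log units; beyond the scatter), so this carbon of the core matters at least as much as the aromatic carbon changed in that earlier step, yet compound 4 still gives a measurable 77 nM. Nothing available from other measurements accounts for the size or direction of this step.

With one group on this carbon, the compounds shown cannot separate an effect of methylsulfonyl itself from an effect of replacing hydrogen with any group there; a methyl, a methoxy or an amine on the same carbon would help to tell these apart. From the compounds shown here alone, it also stays open whether the step would carry over to compound 1, which has hydrogen where compound 3 has its chloro, or to the 2,6-dimethylphenyl series of compound 2.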